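The source may report more compounds than this note shows. Statements on the series, on what has been measured and on what is new or still open speak of the compounds shown alone.

Compound 3 `Cc1ccc(S(=O)(=O)n2c(Cc3cn(C)c4ccccc34)c(C(C)C)c3ccccc32)cc1` was tested in an assay on HepG2 cells for inhibition of Proprotein convertase subtilisin/kexin type 9 (Homo sapiens), read by AlphaLISA, with a stated time of 48 h (on this read-out lower numbers stand for stronger inhibition and higher numbers for weaker inhibition), where compound 3 gives 1100 nM. Among the three numbers known so far, this is the second highest. Its nearest neighbour is compound 2 `Cc1ccc(S(=O)(=O)n2c(Cc3cn(C)c4ccccc34)c(C)c3ccccc32)cc1`, which in this assay gives 1500 nM; these two numbers lie within the scatter of each other, so no order can be read between them. Furthest away is compound 1 `Fc1ccc2[nH]c(Cc3c[nH]c4c(Cl)cccc34)cc2c1`, which in this assay gives 250 nM, a lower number, and that gap lies beyond the scatter.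

Compound 4 `Cc1ccc(S(=O)(=O)n2c(Cc3cn(C)c4ccccc34)c(-c3ccccc3)c3ccccc32)cc1` differs from compound 3 in one place: phenyl in place of isopropyl on an aromatic carbon. Going by the values given here, only one measured step bears on this kind of change, namely a 1.4-fold lower number from compound 2 to compound 3 (0.13 log units; within the scatter), in which isopropyl replaced methyl on an aromatic carbon. That step stayed within the scatter, so enlarging the group on this carbon once before did not move the number noticeably. Among the compounds with values here, no measured pair shows phenyl entering at this place, so the size of the new step is not settled by the data. The expected change in this assay is a 1.2-fold lower number from compound 3 to compound 4 (0.09 log units; within the scatter), which is to say nothing beyond the scatter. Compound 4 is therefore estimated at 900 nM, with a range from 300 nM to 3000 nM.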

Compound 4, half-maximal inhibitory concentration: 2300 nM
The estimate for compound 4 lay 2.6-fold (0.41 log units) below the measured number, within the range that was stated.
By their numbers in this assay, from the lowest: compound 1; then compounds 3, 2 and 4 (each within the scatter of the next, the first and the last beyond it).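

Phenyl, with six carbon atoms in one aromatic ring, in place of isopropyl gives the first step at this aromatic carbon that leaves the scatter in this assay: a 2.1-fold higher number from compound 3 to compound 4 (0.32 log units; beyond the scatter), a modest change towards weaker inhibition. Measured against methyl, however, phenyl gives a 1.5-fold higher number from compound 2 to compound 4 (0.19 log units; within the scatter), so no order can be read between those two groups, and the only separation among methyl, isopropyl and phenyl at this carbon lies between isopropyl and phenyl. The larger ring therefore brought no gain over either smaller group here, and no measurement shown explains the rise seen with phenyl.

Going by these compounds, all three groups at this position contain only carbon and hydrogen, so it remains open how an amine, a carboxylic acid or a longer alkyl chain on this aromatic carbon would read in this assay. On these data alone, it is also open whether a phenyl ring carrying a fluorine or a methoxy group would behave like plain phenyl, and whether the same change would have a similar effect on the core of compound 1.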